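Trifluoromethyl in place of methyl on the shared core

A few compounds are considered here, and "the series" means these few. Any claim that something is new, unique, unknown or untested is made for them only; others in the source may bear on it.

In a functional assay on HL-60 cells (Homo sapiens) for cytotoxicity, read by WST assay, with a stated time of 48 h (on this read-out lower numbers stand for an effect already at smaller amounts and higher numbers for an effect only at larger amounts of compound), compound 1 (`COc1ccc(C[C@H]2C(=O)OC[C@@H]2Cc2ccccc2)cc1`) gives 67000 nM, compound 2 (`COCOc1ccc(C[C@H]2C(=O)OC[C@@H]2Cc2ccccc2)cc1`) gives 71000 nM and compound 3 (`Cc1ccc(C[C@H]2C(=O)OC[C@@H]2Cc2ccccc2)cc1`) gives 44000 nM. Compound 3 stands within the scatter of both others, with a 1.5-fold lower number from compound 1 to compound 3 (0.18 log units; within the scatter) and a 1.6-fold lower number from compound 2 to compound 3 (0.21 log units; within the scatter). The next structure is compound 4 (`O=C1OC[C@H](Cc2ccccc2)[C@H]1Cc1ccc(C(F)(F)F)cc1`), which carries trifluoromethyl in place of methyl on an aromatic carbon, para to a large group: trifluoromethyl in place of methyl on an aromatic carbon.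

The two steps to compound 3 bear most directly on this change, since each replaces the group on that aromatic carbon, and both stay within the scatter. The remaining step, a 1.1-fold higher number from compound 1 to compound 2 (0.03 log units; within the scatter), also stays within it. Among the measured compounds shown here, no measured compound carries trifluoromethyl, so the extrapolation is uncertain. No step beyond the scatter is expected in this assay, and no direction can be called with confidence. The estimated step is a 1.1-fold lower number from compound 3 to compound 4 (0.04 log units; within the scatter). For compound 4 the estimated value is 40000 nM, with an expected range of 18000 nM to 90000 nM.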

Compound 4, half-maximal effective concentration: 22000 nM
The estimate for compound 4 lay 1.8-fold (0.26 log units) above the measured number, and the stated range covers the measured number.
By their numbers in this assay, from the lowest: compounds 4, 3, 1 and 2 (each within the scatter of the next, the first and the last beyond it).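

In this assay, among the compounds shown here, trifluoromethyl on this aromatic carbon, para to a large group, gives the first steps that lie beyond the scatter: a 3.2-fold lower number from compound 2 to compound 4 (0.51 log units; beyond the scatter) and a 3.0-fold lower number from compound 1 to compound 4 (0.48 log units; beyond the scatter) are both modest. Against methyl the same position gives a 2.0-fold lower number from compound 3 to compound 4 (0.30 log units; within the scatter) and stays within the scatter, so compound 4 is not separated from compound 3, and methyl and trifluoromethyl cannot be told apart here. No measurement of any property accompanies these values, and the result has no explanation from the data at hand.

From the compounds shown here alone, it remains open how an amine, a carboxylic acid or a longer chain on this aromatic carbon would read in this assay, and whether any group there separates clearly from both methyl and trifluoromethyl. Going by these compounds, whether these steps carry over to other cell lines is also open.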